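The source may report more compounds than this note shows. Statements on the series, on what has been measured and on what is new or still open speak of the compounds shown alone.

Measured in a functional assay on MES-SA cells (Homo sapiens) for inhibition, with a stated time of 72 h; on this read-out higher numbers stand for weaker inhibition and lower numbers for stronger inhibition:
- Compound 1 `CCN(CC)Cc1cc(Cl)c2cccnc2c1O`: 2970 nM; 2950 nM (2 entries)
- Compound 2 `COCc1cc(CN2CCCC2)c(O)c2ncccc12`: 11000 nM
- Compound 3 `COCc1cc(CN2CCCCC2)c(O)c2ncccc12`: 9330 nM

Going by the values given here, the one measured step, a 1.2-fold lower number from compound 2 to compound 3 (0.07 log units; within the scatter), leaves that pair level with each other. Both values lie higher than the several entries of compound 1 in this assay, 2970 nM; 2950 nM (2 entries), which agree closely. Compound 4 `CCCOCc1cc(CN2CCCCC2)c(O)c2ncccc12` turns methoxymethyl into propoxymethyl: ethyl in place of hydrogen on a saturated chain carbon bound to an oxygen on a saturated carbon. Among the compounds with values here, no step at this place has been measured. Within the data shown here, the only guide is a 1.2-fold lower number from compound 2 to compound 3 (0.07 log units; within the scatter), made elsewhere on the molecule, so no shift beyond the scatter is expected in this assay. The expected change is a 1.3-fold lower number from compound 3 to compound 4 (0.12 log units; within the scatter). Compound 4 is estimated at 7000 nM, with an expected range of 3000 nM to 16000 nM.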

Compound 4, half-maximal inhibitory concentration: 3720 nM
For compound 4 the middle estimate is 1.9-fold (0.27 log units) above the measured one, within the range that was stated.
By their numbers in this assay, from the lowest: compound 4; then compounds 3 and 2 (each within the scatter of the next).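

In this assay the change from methoxymethyl to propoxymethyl gives a step beyond the scatter (a 2.5-fold lower number from compound 3 to compound 4 (0.40 log units; beyond the scatter)), though a modest one. This place on the chain therefore responds to added ethyl, whereas the swap of pyrrolidin-1-yl for piperidin-1-yl did not move the number beyond the scatter (a 1.2-fold lower number from compound 2 to compound 3 (0.07 log units; within the scatter)). Repeat readings in this read-out can agree closely, as seen in: the several entries of compound 1 in this assay, 2970 nM; 2950 nM (2 entries).

With one step at this place, no trend along the chain can be claimed. From the compounds shown here alone, whether a longer chain such as butoxymethyl, or a chain ending in an amine or a carboxylic acid, would shift the number further remains open.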